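The source may report more compounds than this note shows. Statements on the series, on what has been measured and on what is new or still open speak of the compounds shown alone.

Measured so far in a functional assay on PC-3 cells (Homo sapiens) for inhibition, read by MTT assay, with a stated time of 48 h; on this read-out higher numbers stand for weaker inhibition and lower numbers for stronger inhibition
Compound 1 `COc1ccc(-c2coc3cc(OCCCBr)ccc3c2=O)cc1` gives 62600 nM
Compound 2 `COc1ccc(-c2coc3cc(OCCCSC(=S)N4CCCC4)ccc3c2=O)cc1` gives 19400 nM
Compound 3 `COc1ccc(-c2coc3cc(OCCCSC(=S)N4CCOCC4)ccc3c2=O)cc1` gives 27400 nM

Compound 3 stands close to compound 2, and the gap, a 1.4-fold higher number from compound 2 to compound 3 (0.15 log units; within the scatter), stays within the scatter. Both lie clearly under compound 1. The open question concerns compound 4 `COc1ccc(-c2coc3cc(OCCCCBr)ccc3c2=O)cc1`, which has not yet been measured. The change from compound 3 is a group of 2 heavy atoms (1 carbon, 1 bromine; no ring) in place of a group of 9 heavy atoms (5 carbon, 1 nitrogen, 1 oxygen, 2 sulfur; one six-membered non-aromatic ring with 2 hetero atoms), on a saturated chain carbon, three bonds along the chain from an oxygen on an aromatic ring.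

The closest guides are the two steps that put a larger group on the chain in place of bromine. One is a 2.3-fold lower number from compound 1 to compound 3 (0.36 log units; beyond the scatter), and the other is a 3.2-fold lower number from compound 1 to compound 2 (0.51 log units; beyond the scatter). Both are modest but beyond the scatter. Compound 4 again ends in bromine, so the first of these steps, run in reverse, suggests a modest rise in this assay, and a value in the region of compound 1 , which gives 62600 nM. Among the compounds with values here, no measured pair tests the extra carbon that bromomethyl brings in place of a single bromine, so the range is kept wide.

The expected change is a 1.9-fold higher number from compound 3 to compound 4 (0.28 log units; within the scatter). For compound 4 the estimated value is 52000 nM, with an expected range from 24000 nM to 110000 nM.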

Compound 4, half-maximal inhibitory concentration: 55600 nM
Beside the measured number, compound 4's estimate is 1.1-fold (0.03 log units) below it, within the range that was stated.
By their numbers in this assay, from the lowest: compounds 2 and 3 (each within the scatter of the next); then compounds 4 and 1 (each within the scatter of the next).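

In this assay, within the data shown here, the first pair to test the extra carbon gives a 1.1-fold lower number from compound 1 to compound 4 (0.05 log units; within the scatter), so bromomethyl in place of bromo at this chain position leaves compound 1 and compound 4 indistinguishable. The larger groups now also stand apart from this longer bromine-ended chain, with a 2.0-fold higher number from compound 3 to compound 4 (0.31 log units; beyond the scatter) and a 2.9-fold higher number from compound 2 to compound 4 (0.46 log units; beyond the scatter), so both the pyrrolidin-1-yl and the morpholin-4-yl compounds are separated from bromine-ended compounds of either chain length, though each of these two steps alters the end group and the extra carbon together. No independent data bear on what lies behind these numbers.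

The compounds shown leave open how a pyrrolidin-1-yl or morpholin-4-yl group would read on the chain of compound 4, as that chain appears here only with bromine at its end. They also leave open whether a simple amine or a carboxylic acid at the end of the chain would read like the bromine-ended compounds or like compound 2 and compound 3, and whether a still longer chain would continue to read like compound 1.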